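The source may hold more compounds than are shown below. What is called first, only, known or untested is meant among the compounds shown, and "the series" means these compounds.

In a functional assay on MCF7 cells (Homo sapiens) for cytotoxicity, read by MTT assay, with a stated time of 96 h (a higher number here means a weaker inhibitor, a lower number a stronger inhibitor), compound 1 `COc1cccc(-n2cc(C(=O)c3cc(OC)c(OC)c(OC)c3)c(-c3ccccc3)c2)c1` gives 500 nM and compound 2 `COc1ccc(-n2cc(C(=O)c3cc(OC)c(OC)c(OC)c3)c(-c3ccccc3)c2)cc1` gives 120 nM. Compound 3 `COc1cc(C(=O)c2cn(-c3ccccc3)cc2-c2ccccc2Cl)cc(OC)c1OC` gives 76 nM, which is within the scatter of compound 2 and clearly lower than compound 1. Compound 4 `COc1cc(C(=O)c2cn(-c3ccccc3)cc2-c2ccccc2[N+](=O)[O-])cc(OC)c1OC` carries one change from compound 3: nitro in place of chloro on an aromatic carbon. Here the chloro group leaves and the nitro group enters, ortho to a large group. For the measured compounds named here, the only measured step, a 4.2-fold lower number from compound 1 to compound 2 (0.62 log units; beyond the scatter), was modest, but it swaps 3-methoxyphenyl for 4-methoxyphenyl on an aromatic nitrogen, elsewhere in the molecule. Going by the values given here, no measured step touches the 2-chlorophenyl group, and none therefore sizes this change. The expected step, a 1.3-fold higher number from compound 3 to compound 4 (0.12 log units; within the scatter), stays within the scatter in this assay. Compound 4 is expected at 100 nM, with an estimated range of 30 nM to 350 nM.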

Compound 4, half-maximal inhibitory concentration: 49 nM
Estimate against measurement, compound 4: 2.0-fold (0.31 log units) above; the range from low to high includes it.
By their numbers in this assay, from the lowest: compounds 4, 3 and 2 (each within the scatter of the next, the first and the last beyond it); then compound 1.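

In this assay the change from 2-chlorophenyl to 2-nitrophenyl gives a 1.6-fold lower number from compound 3 to compound 4 (0.19 log units; within the scatter) and so shows that nitro, with its three heavy atoms and two hydrogen-bond acceptors, can stand on this aromatic carbon in place of chloro without the number moving beyond the scatter. The earlier step, a 4.2-fold lower number from compound 1 to compound 2 (0.62 log units; beyond the scatter), concerned only the methoxyphenyl group on the aromatic nitrogen and said nothing about this position. No evidence is available on why the two groups read alike.

On these data alone, whether an amine or a carboxylic acid on this carbon would also stay within the scatter remains open. So does the reading of the 2-nitrophenyl group alongside the 4-methoxyphenyl group of compound 2.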